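A few compounds are considered here, and "the series" means these few. Any claim that something is new, unique, unknown or untested is made for them only; others in the source may bear on it.

Measured so far:
compound 1 `COc1ccc(-c2cc(-c3ccc(S(=O)(=O)N(C)C)cc3)cnc2N)cn1`, > 100 ug/mL
compound 2 `COc1ccc(-c2cc(-c3ccc(S(=O)(=O)NC4CC4)cc3)cnc2N)cn1`, > 100 ug/mL
compound 3 `COc1ccc(-c2cc(-c3ccc(S(C)(=O)=O)c(F)c3)cnc2N)cn1`, > 100 ug/mL

Every value here is a limit of a physicochemical assay for solubility, read by nephelometry, measured as kinetic solubility, at pH 2 (on this read-out lower numbers stand for lower solubility and higher numbers for higher solubility), not a number. In this assay compound 1 gives > 100 ug/mL, a limit. Compound 2 gives > 100 ug/mL, also a limit. Compound 3 gives > 100 ug/mL, again a limit. For the measured compounds named here, the only step measured in one place, a step that the two limits leave unreadable from compound 1 to compound 2, is unreadable because of the limit of > 100 ug/mL in this assay, at which 3 of the 3 values shown sit. Compound 4 `COc1ccc(-c2cc(-c3ccc(C(F)(F)F)cc3)cnc2N)cn1` differs from compound 1 by trifluoromethyl in place of dimethylsulfamoyl on an aromatic carbon. Going by the values given here, no measured step bears on this change, and compound 1 is known only as a limit, so an at least 2.5-fold lower number from compound 1 to compound 4 (0.39 log units; beyond the scatter) is expected to be a downward step that cannot be sized from the data. Compound 4 is estimated at 40 ug/mL, in the range 8 ug/mL to 150 ug/mL.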

Compound 4, solubility: > 100 ug/mL
Compound 4: a limit, no number (the forecaster's own chance of this, stated with the estimate: 35%); middle value at least 2.5-fold (0.39 log units) away from the limit.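

For the compounds shown here, compound 4 gives > 100 ug/mL, a limit, so no new step to it from compound 1 or compound 2 can be read: the limit of > 100 ug/mL in this assay, at which 4 of the 4 values shown sit. As far as these compounds go, whether trifluoromethyl and dimethylsulfamoyl differ at all in this assay stays open.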